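Amide nitrogen substituents on the shared core: paw edema inhibition

This account rests on a few compounds, and the source may have more. Where it says the series, first, only, none or still open, it means among the compounds named here.

Measured so far:
compound 1 `COc1ccc(-n2nc(C(N)=O)nc2-c2cc(OC)c(OC)c(OC)c2)cc1` 106%
compound 2 `CNC(=O)c1nc(-c2cc(OC)c(OC)c(OC)c2)n(-c2ccc(OC)cc2)n1` 109%
compound 3 `CCNC(=O)c1nc(-c2cc(OC)c(OC)c(OC)c2)n(-c2ccc(OC)cc2)n1` 101%

Compound 1 carries an unsubstituted amide nitrogen; in a functional assay on the whole organism for inhibition, with Rattus norvegicus as the target, read by paw edema, with stated times of 30 min and 3 h, at a dose of 0.28 mmol/kg by the oral route (a lower number here means less inhibition, a higher number more inhibition at the dose given (going by the name of the read-out)), compound 1 gives 106%. Compound 2 gives 109% and compound 3 gives 101%. The three steps all sit at the amide nitrogen and all stay inside the scatter: a number 3 percentage points higher from compound 1 to compound 2 (within the scatter), a number 5 percentage points lower from compound 1 to compound 3 (within the scatter) and a number 8 percentage points lower from compound 2 to compound 3 (within the scatter). Compound 3 holds the lowest of the three numbers, yet neither of its two neighbours is set apart from it beyond the scatter, so no order among the three can be read.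

Compound 4 `COc1ccc(NC(=O)c2nc(-c3cc(OC)c(OC)c(OC)c3)n(-c3ccc(OC)cc3)n2)cc1` is not yet measured. It differs from compound 3 at the same amide nitrogen: 4-methoxyphenyl in place of ethyl on an amide-type nitrogen

The three measured steps bear on this change in that each of them alters the group on that nitrogen, and none moved the read-out beyond the scatter. The entering group is larger than anything tried there, so the step is less well covered, but the data give no direction. The step of a number 1 percentage points higher from compound 3 to compound 4 (within the scatter) is therefore expected to stay inside the scatter. For compound 4 the estimate is 102%, with a range from 86% to 116%.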

Compound 4, a percentage reported as inhibition, in the whole organism at one dose (the size of the read-out at that dose, not a potency): 99%
Compound 4: middle estimate off by 3 percentage points, on the high side; the range from low to high includes it.
By their numbers in this assay, from the lowest: compounds 4, 3, 1 and 2 (each within the scatter of the next).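

The amide nitrogen now carries one six-membered aromatic ring, and in this assay the step from ethyl to 4-methoxyphenyl stays small: a number 2 percentage points lower from compound 3 to compound 4 (within the scatter). The comparisons with the smaller groups read the same way, a number 10 percentage points lower from compound 2 to compound 4 (within the scatter) and a number 7 percentage points lower from compound 1 to compound 4 (within the scatter), so hydrogen, methyl, ethyl and 4-methoxyphenyl on this nitrogen are not set apart by this read-out at the dose given. No measurement at hand bears on why these four compounds stay together.

Still open, from the compounds shown here alone, is whether a different kind of group on this nitrogen, such as a dimethylaminoethyl chain or a carboxymethyl group, would move the read-out beyond the scatter. With a single dose shown, it is also open whether these four compounds would separate at a lower dose.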